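Moving the nitro group around the benzyl ring

The source may report more compounds than this note shows. Statements on the series, on what has been measured and on what is new or still open speak of the compounds shown alone.

Measured so far:
compound 1 `COc1cccc(OC)c1OCCNCCOc1ccccc1OCc1ccccc1Cl` gives 1.41 nM
compound 2 `COc1cccc(OC)c1OCCNCCOc1ccccc1OCc1ccccc1[N+](=O)[O-]` gives 7.94 nM

In an assay on CHO cells for displacement of a labelled ligand from Alpha-1A adrenergic receptor (Homo sapiens) (a higher number here means a weaker inhibitor, a lower number a stronger inhibitor), compound 2 stands highest of the two numbers; its nearest neighbour is compound 1, and the step of a 5.6-fold higher number from compound 1 to compound 2 (0.75 log units; beyond the scatter) is modest. Compound 3 `COc1cccc(OC)c1OCCNCCOc1ccccc1OCc1cccc([N+](=O)[O-])c1` keeps every atom of compound 2 and differs only by 3-nitrophenyl in place of 2-nitrophenyl on a saturated chain carbon bound to an oxygen on an aromatic ring. Going by the values given here, no measured step changes the place of a group on this ring, so the step of a 5.6-fold higher number from compound 1 to compound 2 (0.75 log units; beyond the scatter) does not bear on it directly, and no other measured step does either. The expected step of a 1.3-fold lower number from compound 2 to compound 3 (0.10 log units; within the scatter) is therefore small, within the scatter in either direction. Compound 3 is estimated at 6.3 nM, likely between 2 nM and 20 nM.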

Compound 3, inhibition constant: 0.316 nM
Beside the measured number, compound 3's estimate is 20-fold (1.30 log units) above it, and the stated range ends above it.
By their numbers in this assay, from the lowest: compound 3; then compound 1; then compound 2.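

In this assay, the change from 2-nitrobenzyl to 3-nitrobenzyl gives a 25-fold lower number from compound 2 to compound 3 (1.40 log units; beyond the scatter), so moving one group on this ring, with the same atoms, can by itself shift the number strongly. The nitro group is also not a drawback in every placement, since the comparison with the chloro compound gives a 4.5-fold lower number from compound 1 to compound 3 (0.65 log units; beyond the scatter). Nothing available explains why the placement matters so much. As far as these compounds go, whether the chloro group of compound 1 would respond to the same move remains open. So does how an amine or a carboxylic acid would fare in place of the nitro group.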